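Anilinoquinazoline amide series: halogen in place of methyl

The compounds below may be only part of what the source reports. "The series", "measured", "known", "first", "only" and "open" are said of these compounds alone.

Measured compounds, with values in a functional assay on HepG2 cells (Homo sapiens) for inhibition, read by MTT assay; a higher number here means a weaker inhibitor, a lower number a stronger inhibitor:
compound 1, `COc1cc2ncnc(Nc3ccc(NC(=O)c4ccc(C)cc4)cc3)c2cc1OC`: 25000 nM
compound 2, `COc1cc2ncnc(Nc3ccc(NC(=O)c4ccc(F)cc4)cc3)c2cc1OC`: 15000 nM
compound 3, `COc1cc2ncnc(Nc3ccc(NC(=O)c4ccccc4Cl)cc3)c2cc1OC`: 26000 nM

Compound 1 stands second highest of the three numbers; its nearest neighbour is compound 3 at 26000 nM, and its furthest is compound 2 at 15000 nM, both within the scatter of compound 1. The three compounds thus give no ordering that can be trusted.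

Compound 4, `COc1cc2ncnc(Nc3ccc(NC(=O)c4ccc(I)cc4)cc3)c2cc1OC`, has not been measured. It differs from compound 1 as follows: iodo in place of methyl on an aromatic carbon. The step that bears most directly on it is the exchange of the same methyl for another halogen, fluoro: a 1.7-fold lower number from compound 1 to compound 2 (0.22 log units; within the scatter). The exchanges of the whole aryl group, a 1.0-fold higher number from compound 1 to compound 3 (0.02 log units; within the scatter) and a 1.7-fold higher number from compound 2 to compound 3 (0.24 log units; within the scatter), also stayed within the scatter. Among the compounds with values here, nothing among the measured compounds suggests that a different halogen at this position should move the number beyond the scatter.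

The step from compound 1 to compound 4 is therefore expected to be small, a 1.3-fold lower number from compound 1 to compound 4 (0.10 log units; within the scatter), with no trusted direction. The value of compound 4 is estimated at 20000 nM, within a range of 8000 nM to 50000 nM.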

Compound 4, half-maximal inhibitory concentration: 40000 nM
The estimate for compound 4 lay 2.0-fold (0.30 log units) below the measured number; low and high end bracket the measured number.
By their numbers in this assay, from the lowest: compounds 2, 1, 3 and 4 (each within the scatter of the next, the first and the last beyond it).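

In this assay, within the data shown here, the exchange of one halogen for another on this aromatic carbon, para to a large group, gives the only step that clears the scatter, and only modestly: a 2.7-fold higher number from compound 2 to compound 4 (0.43 log units; beyond the scatter). The other two new steps stay within the scatter: a 1.6-fold higher number from compound 1 to compound 4 (0.20 log units; within the scatter), and a 1.5-fold higher number from compound 3 to compound 4 (0.19 log units; within the scatter), so neither the exchange of methyl for iodo nor that of the whole aryl group gives a trusted change. Nothing at hand accounts for the gap between fluoro and iodo at this position.

On these data alone, with only fluoro and iodo on this carbon, it stays open whether 4-chlorophenyl or 4-bromophenyl would fall between compound 2 and compound 4. Also open, as far as these compounds go, is how an amine or a carboxylic acid at this position would read.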